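Branching the Chain End of Compound 3

The source may report more compounds than this note shows. Statements on the series, on what has been measured and on what is new or still open speak of the compounds shown alone.

The three measured compounds were tested in a functional assay on HEK293 cells for agonist activity at G-protein coupled receptor 84 (Homo sapiens), read by calcium flux; on this read-out higher numbers stand for an effect only at larger amounts of compound and lower numbers for an effect already at smaller amounts. Compound 1 `Oc1cc(C(F)(F)F)nc(SCCCCc2ccccc2)n1` returned only > 100000 nM, which is a limit of the assay rather than a number (the limit of > 100000 nM in this assay, at which 1 of the 3 values shown sits). Compound 2 `CCCCCCCCc1cc(O)nc(O)n1` carries an unbranched octyl chain on the shared core and gives 811 nM in this assay. Compound 3 `CCCCCCc1nc(O)cc(O)n1` carries a hexyl chain on the same core and gives 454 nM in this assay, the lowest of the two numbers that were obtained; compound 2 stands within the usual scatter of it, so the two cannot be ranked against each other.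

Compound 4 `CC(C)CCCc1nc(O)cc(O)n1` has the same atoms as compound 3, joined differently: isopropyl in place of propyl on a saturated chain carbon, three bonds along the chain from an aromatic carbon. Within the data shown here, no step between two measured compounds is available to calibrate a change of this kind, so the expectation rests on the closeness of compound 2 and compound 3 alone. The step of a 1.5-fold higher number from compound 3 to compound 4 (0.19 log units; within the scatter) is expected to be small, most likely none beyond the scatter, since the chain length of compound 3 is kept and only its end is branched. Compound 4 is therefore estimated at 700 nM in this assay, with a range from 200 nM to 2500 nM.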

Compound 4, half-maximal effective concentration: 2110 nM
For compound 4 the middle estimate is 3.0-fold (0.48 log units) below the measured one; low and high end bracket the measured number.
By their numbers in this assay, from the lowest: compounds 3 and 2 (each within the scatter of the next); then compound 4. At a limit, above all of these: compound 1.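

Branching the chain end gives the first step in this series that can be read between two measured compounds: in this assay, isopropyl in place of propyl on a saturated chain carbon, three bonds along the chain from an aromatic carbon, gives a 4.6-fold higher number from compound 3 to compound 4 (0.67 log units; beyond the scatter) and so lies beyond the scatter. The two compounds hold the same atoms, so this position responds to how the chain end is joined, and not only to which atoms the chain carries, though this is one change at one place and no general rule follows from it. No measurement shown here bears on why the branched end raises the number.

On these data alone, it remains open whether this step belongs to branching as such or to this one isopropyl end, and whether a tert-butyl or a cyclopropyl at the end of the chain, or a methyl branch nearer the core, would go the same way. As far as these compounds go, it is equally open how an amine, a hydroxyl or a carboxylic acid at the chain end would read on this core.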